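Dimethylpiperazine Isomers on a Chemokine Receptor Antagonist Core

A few compounds are considered here, and "the series" means these few. Any claim that something is new, unique, unknown or untested is made for them only; others in the source may bear on it.

Measured so far:
compound 1 `CCCN(C[C@H]1Cc2c(cccc2N2CCNCC2)CN1)[C@H]1CCCc2cccnc21`: 32.2 nM
compound 2 `C[C@@H]1CN(c2cccc3c2C[C@H](CN(C)[C@H]2CCCc4cccnc42)NC3)C[C@H](C)N1`: 61 nM
compound 3 `CN(C[C@H]1Cc2c(cccc2N2CCN(c3cccc(C(F)(F)F)c3)CC2)CN1)[C@H]1CCCc2cccnc21`: > 16700 nM

In a functional assay on CCRF-CEM cells for antagonist activity at C-X-C chemokine receptor type 4 (Homo sapiens), read by calcium flux, with stated times of 25 min and 90 s (a lower number here means a stronger inhibitor, a higher number a weaker inhibitor), compound 2 gives 61 nM, and compound 1 gives 32.2 nM, a difference that lies within the usual scatter of this kind of measurement. For compound 3 the value > 16700 nM is a limit of the assay, not a number. Compound 4 `CN(C[C@H]1Cc2c(cccc2N2CCNC(C)(C)C2)CN1)[C@H]1CCCc2cccnc21` has not yet been measured. 3,3-dimethylpiperazin-1-yl in place of 3,5-dimethylpiperazin-1-yl on an aromatic carbon The two groups carry the same atoms, joined differently. Going by the values given here, no measured pair isolates this change, so the size of the step is uncertain; the expected step from compound 2 to compound 4 is a 1.4-fold higher number from compound 2 to compound 4 (0.14 log units; within the scatter), close to the scatter and slightly towards a weaker inhibitor. Compound 4 is therefore estimated at 85 nM, with a range from 25 nM to 300 nM.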

Compound 4, half-maximal inhibitory concentration: 33.9 nM
For compound 4 the middle estimate is 2.5-fold (0.40 log units) above the measured one; measured number inside the range.
By their numbers in this assay, from the lowest: compounds 1, 4 and 2 (each within the scatter of the next). At a limit, above all of these: compound 3.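

In this assay, gathering the two methyl groups onto one ring carbon, as 3,3-dimethylpiperazin-1-yl in place of 3,5-dimethylpiperazin-1-yl, gives a 1.8-fold lower number from compound 2 to compound 4 (0.26 log units; within the scatter), so the two isomers cannot be told apart here. The group on this aromatic carbon can therefore lose its 2 defined stereocentres without a measurable change in this assay. No measurement shown explains why the two isomers read alike.

Still open is how a morpholine ring or a 4-methylpiperazin-1-yl group would read on this aromatic carbon, since neither is among the compounds shown.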